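Replacing sulfanylmethyl on the shared core of compound 3

The source may hold more compounds than are shown below. What is called first, only, known or untested is meant among the compounds shown, and "the series" means these compounds.

Measured compounds in a functional assay (aorta) for inhibition, with Rattus norvegicus as the target (on this read-out higher numbers stand for weaker inhibition and lower numbers for stronger inhibition), follow.
- Compound 1 (`CC/N=C(\S)[C@]1(c2cccnc2)CCCC[S+]1[O-]`) gives 300 nM as a number
- Compound 2 (`[O-][S+]1CCCC[C@]1(CO)c1cccnc1`) gives > 30000 nM as a limit
- Compound 3 (`[O-][S+]1CCCC[C@]1(CS)c1cccnc1`) gives > 30000 nM as a limit

Compound 3 has only a limit, and it stands at the limit of > 30000 nM in this assay, at which 2 of the 3 values shown sit, here. Compound 4 (`COC(=N)[C@]1(c2cccnc2)CCCC[S+]1[O-]`) carries a group of 4 heavy atoms (2 carbon, 1 nitrogen, 1 oxygen; no ring) in place of a group of 2 heavy atoms (1 carbon, 1 sulfur; no ring), on a saturated ring carbon on a saturated ring carbon next to the ring sulfur. Within the data shown here, two measured steps bear on this: an at least 100-fold higher number from compound 1 to compound 2 (2.00 log units; beyond the scatter) and an at least 100-fold higher number from compound 1 to compound 3 (2.00 log units; beyond the scatter) are both large. The step that the two limits leave unreadable from compound 2 to compound 3 adds nothing. The group in compound 4 is nearer in heavy-atom count to that of compound 1, so a move to a lower number is expected, though probably only part of an at least 100-fold higher number from compound 1 to compound 3 (2.00 log units; beyond the scatter) in size. The expected step is an at least 6.0-fold lower number from compound 3 to compound 4 (0.77 log units; beyond the scatter) in this assay overall. Compound 4 is estimated at 5000 nM as a middle value. The expected range for it runs from 700 nM to 30000 nM in all.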

Compound 4, concentration for 90% inhibition: > 30000 nM
Compound 4: no number, only a limit; the forecaster's own chance of this, stated with the estimate: 30%; middle value at least 6.0-fold (0.77 log units) from the limit.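

In this assay compound 4 gives only a limit, and it joins the other compounds there: the limit of > 30000 nM in this assay, at which 3 of the 4 values shown sit. The steps to compound 4 from compound 2 and from compound 3 cannot be read. The step of an at least 100-fold higher number from compound 1 to compound 4 (2.00 log units; beyond the scatter) shows that a group closer in heavy-atom count to that of compound 1 still gives no measurable number on this saturated ring carbon, so heavy-atom count alone does not separate these groups. Going by these compounds, how much of the group in compound 1 is needed remains open, and so does whether an amine, a carboxylic acid or a longer chain at this position would give a number.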